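The source may report more compounds than this note shows. Statements on the series, on what has been measured and on what is new or still open speak of the compounds shown alone.

In a physicochemical assay for solubility (a higher number here means a more soluble compound, a lower number a less soluble compound), compound 3 `CNC(=O)c1cc(C(=O)N[C@H]2[C@@H]3C[C@@H](O)C[C@@H]32)cc2c1OC[C@H]2c1ccccc1` stands only at a limit, >= 124 ug/mL. Compound 2 `CNC(=O)c1cc(C(=O)N[C@H]2[C@@H]3COC[C@@H]32)cc2c1OC[C@H]2c1ccccc1` is also known only as a limit, >= 165 ug/mL. Compound 1 `CNC(=O)c1cc(C(=O)NC2CC2)cc2c1OC[C@H]2c1cccc(OC)c1` is likewise a limit, >= 161 ug/mL. Going by the values given here, no numerical read-out is therefore available so far. Compound 4 `CNC(=O)c1cc(C(=O)Nc2cnn(C)c2)cc2c1OC[C@H]2c1ccccc1` differs from compound 3 on the amide-type nitrogen: a group of 6 heavy atoms (4 carbon, 2 nitrogen; one five-membered aromatic ring with 2 hetero atoms) in place of a group of 7 heavy atoms (6 carbon, 1 oxygen; one three-membered non-aromatic ring of carbon only, one five-membered non-aromatic ring of carbon only), on an amide-type nitrogen. Among the compounds with values here, the only measured step at that place is a step that the two limits leave unreadable from compound 2 to compound 3, so it gives no size to carry over. Within the data shown here, no measured step brings 1-methyl-1H-pyrazol-4-yl onto that nitrogen, which leaves the expectation loose. The estimated step is an at least 1.2-fold lower number from compound 3 to compound 4 (0.09 log units; that floor lies within the scatter), an expected modest fall of uncertain size. For compound 4 the expected value is 100 ug/mL. The estimated range for compound 4 runs from 35 ug/mL to 175 ug/mL.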

Compound 4, solubility: >= 189 ug/mL
Compound 4: no number, only a limit; the forecaster's own chance of this, stated with the estimate: 35%; at least 1.8-fold (0.27 log units) between middle value and limit.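

Compound 4 stands only at a limit in this assay, and the steps to it from compound 2 and from compound 3 cannot be read. The compounds shown leave open whether 1-methyl-1H-pyrazol-4-yl on the amide-type nitrogen changes the read-out at all.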